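The source may report more compounds than this note shows. Statements on the series, on what has been measured and on what is new or still open speak of the compounds shown alone.

Compound 1 `COc1cc(-n2cnc3ccc(-c4ccccc4)cc32)cc(OC)c1OC`: in a functional assay on A549 cells (Homo sapiens) for antiproliferative activity, read by MTT assay, with a stated time of 72 h (a lower number here means a stronger inhibitor, a higher number a weaker inhibitor), compound 1 gives 3060 nM.
Compound 2 `COc1cc(-n2cnc3ccc(-c4ccc(Cl)cc4Cl)cc32)cc(OC)c1OC`: in this assay compound 2 reaches only the limit > 10000 nM.

Compound 2 stands at the weak end of the two measured values; its result is a limit of this assay and not a number, as recorded in the limit of > 10000 nM in this assay, at which 1 of the 2 values shown sits. Compound 3 `COc1cc(-n2cnc3ccc(-c4ccc(O)cc4)cc32)cc(OC)c1OC` differs from compound 2 in one place: 4-hydroxyphenyl in place of 2,4-dichlorophenyl on an aromatic carbon. For the measured compounds named here, the only measured step bearing on this position is an at least 3.2-fold higher number from compound 1 to compound 2 (0.51 log units; beyond the scatter), which lies beyond the scatter. Compound 3 removes that 2,4-dichlorophenyl, so a return toward the value of compound 1 is expected, while the 4-hydroxyphenyl itself has no measured counterpart among these compounds. The expected step is therefore an at least 2.5-fold lower number from compound 2 to compound 3 (0.39 log units; beyond the scatter), toward a lower number; its size is not fixed, as compound 2 sits at a limit. Compound 3 is thus estimated at 4000 nM, with a range from 1200 nM to 15000 nM.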

Compound 3, half-maximal inhibitory concentration: 5090 nM
Compound 3: the middle estimate sits 1.3-fold (0.10 log units) below what was measured; the measured number falls inside the stated range.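

For the compounds shown here, at this position on the shared core, the earlier compounds showed only that 2,4-dichlorophenyl in place of phenyl costs activity, and compound 3 shows that a substituent on this ring need not do so: hydroxy in place of hydrogen gives a 1.7-fold higher number from compound 1 to compound 3 (0.22 log units; within the scatter), so in this assay the 4-hydroxyphenyl cannot be told apart from the phenyl. Replacing the 2,4-dichlorophenyl with 4-hydroxyphenyl gives an at least 1.9-fold lower number from compound 2 to compound 3 (0.29 log units; that floor lies within the scatter), so this step alone does not firmly separate the two compounds. Compound 2 is a limit of the assay and not a number: the limit of > 10000 nM in this assay, at which 1 of the 3 values shown sits.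

Which of the two chlorine atoms in the 2,4-dichlorophenyl matters, or whether both do, stays open, since neither 4-chlorophenyl nor 2-chlorophenyl stands among these compounds. Also open, as far as these compounds go, is what an amine or a carboxylic acid on this ring would give.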